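The source may hold more compounds than are shown below. What is called first, only, known or untested is meant among the compounds shown, and "the series" means these compounds.

Compound 1 `COc1c(Br)cc(Br)cc1C(=O)Nc1ccccc1` returns only a limit in an ADME assay on HEK293 cells (Homo sapiens) for cytotoxicity, read by reporter gene assay and resazurin assay, with a stated time of 48 h (on this read-out lower numbers stand for higher toxicity in this test and higher numbers for lower toxicity in this test), namely > 100000 nM. Compound 2 `COc1c(Br)cccc1C(=O)Nc1ccccc1` likewise returns only a limit in this assay, namely > 100000 nM. The change from compound 1 to compound 2 is hydrogen in place of bromo on an aromatic carbon, and the resulting step that the two limits leave unreadable from compound 1 to compound 2 cannot be read because the limit of > 100000 nM in this assay, at which 2 of the 3 values shown sit, covers both of its ends. Among the compounds with values here, compound 3 `O=C(Nc1cccc(Cl)c1)c1cc(Br)cc(Br)c1` is the one compound with a number in this assay, where compound 3 gives 53000 nM. The difference between the core of compound 1 and the core of compound 3 is not broken down here. Compound 4 `O=C(Nc1cccc(Cl)c1)c1cccc(Br)c1` is not yet measured; it differs from compound 3 by hydrogen in place of bromo on an aromatic carbon. This is the same kind of change as that from compound 1 to compound 2, not the same change: in compound 1 the place is meta to a group of 9 heavy atoms and para to a methoxy group, whereas in compound 3 it is meta to a large group. The measured step gives no readable size to carry over. For compound 4 the expected step of a 1.5-fold higher number from compound 3 to compound 4 (0.18 log units; within the scatter) is estimated as modest, resting on compound 3 with 53000 nM as the only numbered anchor. Compound 4 is expected near 80000 nM, estimated between 35000 nM and 200000 nM.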

Compound 4, half-maximal cytotoxic concentration: 51000 nM
For compound 4 the middle estimate is 1.6-fold (0.20 log units) above the measured one, and the stated range covers the measured number.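

Hydrogen in place of bromo on an aromatic carbon gives a 1.0-fold lower number from compound 3 to compound 4 (0.02 log units; within the scatter) in this assay, so on the core of compound 3 the two compounds cannot be told apart in this read-out. The same kind of swap on the core of compound 1 cannot be read, because both of its ends sit at a limit of the assay: the limit of > 100000 nM in this assay, at which 2 of the 4 values shown sit. This leaves one readable instance on one core, which shows how the swap reads there but does not show that it carries over to the core of compound 1 or to any other core in the series.

No pair shown isolates the methoxy group of compound 1 and compound 2 or the chloro group of compound 3 and compound 4, so what either group contributes in this assay stays open. Also open, as far as these compounds go, is how compound 4 would read with an amine or a carboxylic acid instead of its remaining bromo group.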